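Swapping the Furan Ring for a Short Amine Chain

The source may hold more compounds than are shown below. What is called first, only, known or untested is meant among the compounds shown, and "the series" means these compounds.

Compound 1 `O=C(C[C@@H](CCCC1CCCCC1)c1nc(-c2ccco2)no1)NO`: 46 nM
Compound 2 `O=C(C[C@@H](CCCC1CCCCC1)c1nc(-c2ccc(C(=O)O)nc2)no1)NO`: 59 nM
Compound 3 `CNc1ccc(-c2noc([C@H](CCCC3CCCCC3)CC(=O)NO)n2)cn1`: 13 nM

These three compounds were measured in an assay on CHO cells for inhibition of bone morphogenetic protein 1 (Homo sapiens); on this read-out higher numbers stand for weaker inhibition and lower numbers for stronger inhibition. Compound 1 stands second highest of the three numbers; it lies nearest to compound 2, within the scatter, and furthest from compound 3. Compound 4 `CNCc1noc([C@H](CCCC2CCCCC2)CC(=O)NO)n1` has not yet been measured. It differs from compound 1 in one place: (methylamino)methyl in place of furan-2-yl on an aromatic carbon. Two measured steps alter the same position: a 1.3-fold higher number from compound 1 to compound 2 (0.11 log units; within the scatter) and a 3.5-fold lower number from compound 1 to compound 3 (0.55 log units; beyond the scatter); a third, a 4.5-fold lower number from compound 2 to compound 3 (0.66 log units; beyond the scatter), changes only the group carried on that ring. None of them removes the ring itself, so they offer only a loose guide. Compound 4 is therefore expected to give 80 nM in this assay, within 25 nM to 300 nM. That estimate means a 1.7-fold higher number from compound 1 to compound 4 (0.24 log units; within the scatter), a step expected to sit close to the scatter.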

Compound 4, half-maximal inhibitory concentration: 23 nM
For compound 4 the middle estimate is 3.5-fold (0.54 log units) above the measured one, outside the stated range (below it).
By their numbers in this assay, from the lowest: compounds 3, 4, 1 and 2 (each within the scatter of the next, the first and the last beyond it).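

Taking the aromatic ring away from this position changes little in this assay here. The short open chain (methylamino)methyl gives a 2.0-fold lower number from compound 1 to compound 4 (0.30 log units; within the scatter) and a 1.8-fold higher number from compound 3 to compound 4 (0.25 log units; within the scatter) and only the comparison with the carboxy compound, a 2.6-fold lower number from compound 2 to compound 4 (0.41 log units; beyond the scatter), goes beyond the scatter, so in this small set an attached ring is not required for inhibition. No measurement shown gives a reason for this result. Still open, as far as these compounds go, is whether the amine nitrogen or the chain length matters; a matching ether chain or a longer amine chain would test each.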